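Benzothiadiazinone N-alkoxymethyl analogues against a leukaemia cell line

The compounds below may be only part of what the source reports. "The series", "measured", "known", "first", "only" and "open" are said of these compounds alone.

Compound 1, `CC(=O)OCCOCN1c2ccccc2C(=O)NS1(=O)=O`, gives in a functional assay on CCRF-CEM cells (Homo sapiens) for cytotoxicity (on this read-out lower numbers stand for higher toxicity in this test and higher numbers for lower toxicity in this test), only the assay's limit, > 200 ug/mL.
Compound 2, `CCCOCN1c2ccccc2C(=O)NS1(=O)=O`, likewise gives in this assay only the limit, > 200 ug/mL.
Compound 3, `O=C1c2ccccc2N(COCCO)S(=O)(=O)N1Cc1ccccc1`, gives in this assay a measured value, 89 ug/mL.

Compound 3 therefore holds the only numerical result; the other two entries are limits, as noted in the limit of > 200 ug/mL in this assay, at which 2 of the 3 values shown sit. Within the data shown here, the single measured step, a step that the two limits leave unreadable from compound 1 to compound 2, runs between two limits and its size cannot be read.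

Compound 4, `C#CCOCN1c2ccccc2C(=O)N(Cc2ccccc2)S1(=O)=O`, differs from compound 3 by ethynyl in place of hydroxymethyl on a saturated chain carbon bound to an oxygen on a saturated carbon. No measured step covers this change, and the step from compound 1 to compound 2 gives no readable size, so nothing in the shown data points to a direction beyond the scatter. The expected step is therefore a 1.1-fold lower number from compound 3 to compound 4 (0.05 log units; within the scatter), essentially no change beyond the scatter, though a limit cannot be excluded. Compound 4 is estimated at 80 ug/mL, within 30 ug/mL to 200 ug/mL.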

Compound 4, half-maximal cytotoxic concentration: 23 ug/mL
The estimate for compound 4 lay 3.5-fold (0.54 log units) above the measured number; measured number outside the range, below it.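

In this assay, among these compounds, ethynyl in place of hydroxymethyl on a saturated chain carbon bound to an oxygen on a saturated carbon gives a 3.9-fold lower number from compound 3 to compound 4 (0.59 log units; beyond the scatter), the first readable step, and it runs towards higher toxicity in this test. Unlike hydroxymethyl, ethynyl has no hydrogen-bond donor or acceptor and brings a triple bond, but this single pair cannot show which of these differences matters. The step from compound 1 to compound 2 still cannot be read, as both values are limits of the assay and not numbers: the limit of > 200 ug/mL in this assay, at which 2 of the 4 values shown sit.

The compounds shown leave open whether the same change would give a similar step on the core of compound 1. They also leave open how an amine, a carboxylic acid or a longer chain ending in ethynyl would behave at this place.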